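This account rests on a few compounds, and the source may have more. Where it says the series, first, only, none or still open, it means among the compounds named here.

Measured so far:
- compound 1, `CCCCCn1c(-c2ccco2)nc2c(NCCOC)ccnc21`: > 200000 nM
- compound 2, `CCCCCn1c(-c2ccco2)nc2c(NCCCOC)ccnc21`: 34200 nM
- compound 3, `COCCNc1nccc2c1nc(-c1ccco1)n2C1CCCC1`: 192000 nM

All three were tested in an assay on isolated protein for inhibition of high affinity 3',5'-cyclic-AMP phosphodiesterase 7A (Homo sapiens), read by cAMP accumulation, with a stated time of 20 min; on this read-out higher numbers stand for weaker inhibition and lower numbers for stronger inhibition. For compound 1 the value is a limit of the assay and not a number: the limit of > 200000 nM in this assay, at which 1 of the 3 values shown sits. In this assay compound 2 gives 34200 nM, and compound 3 gives 192000 nM. Compound 1 and compound 2 share a core and differ in one place, (methoxymethyl in place of methoxy on a saturated chain carbon, two bonds along the chain from a nitrogen on an aromatic ring). That change brought an at least 5.8-fold lower number from compound 1 to compound 2 (0.76 log units; beyond the scatter). Compound 3 is built on a different core, and how its core differs from that of compound 1 is not broken down here. Compound 4, `COCCCNc1nccc2c1nc(-c1ccco1)n2C1CCCC1`, has not yet been measured. It stands to compound 3 as compound 2 stands to compound 1, namely (methoxymethyl in place of methoxy on a saturated chain carbon, two bonds along the chain from a nitrogen on an aromatic ring). The place of the change is described in the same words for both pairs, so it is the same change made on a second core. The step from compound 3 to compound 4 is expected to be about a 5.5-fold lower number from compound 3 to compound 4 (0.74 log units; beyond the scatter) in this assay, resting on the earlier step of an at least 5.8-fold lower number from compound 1 to compound 2 (0.76 log units; beyond the scatter) and on the value of compound 3, 192000 nM. Compound 4 is therefore estimated to give 35000 nM in this assay, most likely between 10000 nM and 130000 nM.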

Compound 4, half-maximal inhibitory concentration: 142000 nM
For compound 4 the middle estimate is 4.1-fold (0.61 log units) below the measured one; measured number outside the range, above it.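

In this assay, going from (2-methoxyethyl)amino to (3-methoxypropyl)amino on the second core gave a 1.4-fold lower number from compound 3 to compound 4 (0.13 log units; within the scatter), so the clear gain seen on the first core did not carry over at the same size, and the two steps differ: the same change on two cores in this assay, an at least 5.8-fold lower number (0.76 log units; beyond the scatter) from compound 1 to compound 2 and a 1.4-fold lower number (0.13 log units; within the scatter) from compound 3 to compound 4, at least 4.3-fold (0.63 log units) apart, beyond the scatter of two such steps

This shows that the effect of this change depends on the core it sits on, at least for these two cores, but with one pair per core it gives no general rule and does not show which feature of the cores makes the difference. Compound 1 stands at a limit of the assay and not at a number, so the earlier step has a bound and no exact size: the limit of > 200000 nM in this assay, at which 1 of the 4 values shown sits.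

The compounds shown leave open how a longer chain, such as (4-methoxybutyl)amino, would behave on each core, and whether an amine or a carboxylic acid at the end of the chain in place of the methoxy would separate the two cores further. They also leave open which of the two steps, if either, a third core would follow.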